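The source may hold more compounds than are shown below. What is called first, only, known or untested is meant among the compounds shown, and "the series" means these compounds.

In an ADME assay on microsomes from liver (Rattus norvegicus, strain Sprague-Dawley) for metabolic stability, read by LC-MS, using NADPH, with a stated time of 45 min, tested at 3 uM (a higher number here means that the compound lasts longer, a lower number that the compound disappears faster), compound 1 `C1CCC(C(CC2CCCCN2)C2CCC2)CC1` has a half-life of 0.167 h and compound 2 `C1CCC(C(CC2CCCCN2)C2CCOCC2)CC1` has a half-life of 0.517 h which places compound 2 as the higher of the two. Compound 3 `FC1CCC(C(CC2CCCCN2)C2CCCCC2)CC1` keeps the shared core and changes one group: 4-fluorocyclohexyl in place of oxan-4-yl on a saturated chain carbon bound to a saturated chain carbon and a saturated ring carbon so the oxan-4-yl of compound 2 gives way to a ring of carbon only. For the measured compounds named here, one measured step bears on this change, namely a 3.1-fold higher number from compound 1 to compound 2 (0.49 log units; beyond the scatter) where oxan-4-yl took the place of cyclobutyl. Going by the values given here, compound 3 reverses that replacement only in part, since no measured compound carries 4-fluorocyclohexyl, and a single step is thin evidence. A drop is still the likelier direction, as the one carbon-only ring measured so far, in compound 1, stands at 0.167 h in this assay and lies under compound 2. The expected change is a 1.9-fold lower number from compound 2 to compound 3 (0.28 log units; within the scatter) and so somewhat smaller than the step from cyclobutyl to oxan-4-yl, though its size is uncertain. Compound 3 is estimated at 0.27 h with an expected range of 0.12 h to 0.6 h for its half-life.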

Compound 3, half-life: 0.183 h
The estimate for compound 3 lay 1.5-fold (0.17 log units) above the measured number; low and high end bracket the measured number.
By their numbers in this assay, from the lowest: compounds 1 and 3 (each within the scatter of the next); then compound 2.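

In this assay, a 2.8-fold lower number from compound 2 to compound 3 (0.45 log units; beyond the scatter), a step beyond the scatter, so at this place on a saturated chain carbon the higher number seen with oxan-4-yl does not carry over to 4-fluorocyclohexyl. Against cyclobutyl the change is a 1.1-fold higher number from compound 1 to compound 3 (0.04 log units; within the scatter), which lies within the scatter: the two carbon-only rings, one larger and carrying fluorine, cannot be told apart here, and among these three compounds oxan-4-yl alone stands apart from both. No measurement at hand accounts for this difference between oxan-4-yl and the two carbon-only rings.

Since 4-fluorocyclohexyl differs from oxan-4-yl both in its ring atoms and in its fluorine, the three compounds cannot show whether the ring oxygen alone sets compound 2 apart, and a plain cyclohexyl at this place would separate those two changes. As far as these compounds go, it also remains open whether a different hetero atom or group on the ring, such as the nitrogen of a piperidin-4-yl or a hydroxyl group on a cyclohexyl ring, would stand with oxan-4-yl or with the carbon-only rings.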